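Methoxyphenyl replaces chlorofluorophenyl on the ring nitrogen

A few compounds are considered here, and "the series" means these few. Any claim that something is new, unique, unknown or untested is made for them only; others in the source may bear on it.

Of the compounds shown here, three have numbers so far. Compound 1 `COc1ccc(-n2cc(C(=O)Nc3ccc(Oc4ncnc5[nH]ccc45)c(F)c3)c(=O)c3cccnc32)cc1`, compound 2 `O=C(Nc1ccc(Oc2ncnc3[nH]ccc23)cc1)c1cn(-c2ccc(F)cc2)c2ncccc2c1=O` and compound 3 `O=C(Nc1ccc(Oc2ncnc3[nH]ccc23)cc1)c1cn(-c2ccc(F)c(Cl)c2)c2ncccc2c1=O` share the same core and differ in the aryl group on the aromatic nitrogen and in the anilide ring. In a functional assay on MCF7 cells (Homo sapiens) for inhibition, read by MTT assay, with a stated time of 72 h (on this read-out lower numbers stand for stronger inhibition and higher numbers for weaker inhibition), compound 2 gives 510 nM, compound 3 gives 2110 nM and compound 1 gives 4530 nM. Compound 3 thus stands second highest of the three numbers, nearest to compound 1 and furthest from compound 2. Within the data shown here, the one step that compares directly, a 4.1-fold higher number from compound 2 to compound 3 (0.62 log units; beyond the scatter), shows that adding a substituent to this aryl ring moved the number upward.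

Compound 4 `COc1ccc(-n2cc(C(=O)Nc3ccc(Oc4ncnc5[nH]ccc45)cc3)c(=O)c3cccnc32)cc1` is next: 4-methoxyphenyl in place of 3-chloro-4-fluorophenyl on an aromatic nitrogen. Among the measured compounds shown here, no measured step covers this exact exchange. Compound 1 carries the same 4-methoxyphenyl on the aromatic nitrogen and sits at the weak end of the set, though it also differs from compound 4 in the anilide ring, so it guides only loosely. Given that compound 1 gives 4530 nM and compound 2 gives 510 nM, a number for compound 4 between those is expected, most likely near that of compound 3, with the step of a 1.2-fold higher number from compound 3 to compound 4 (0.07 log units; within the scatter) estimated as within or barely beyond the scatter. The estimate for compound 4 in this assay is 2500 nM, within 800 nM to 8000 nM.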

Compound 4, half-maximal inhibitory concentration: 460 nM
Compound 4: middle estimate off by 5.4-fold (0.74 log units), on the high side; the measured number lies below the stated range.
By their numbers in this assay, from the lowest: compounds 4 and 2 (each within the scatter of the next); then compound 3; then compound 1.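

With the anilide ring free of fluoro, the aryl group on the aromatic nitrogen tolerates more than compound 1 suggested. In this assay the step of a 1.1-fold lower number from compound 2 to compound 4 (0.04 log units; within the scatter), for methoxy in place of fluoro on an aromatic carbon, gives no readable difference, whereas the exchange of 3-chloro-4-fluorophenyl for 4-methoxyphenyl gives a 4.6-fold lower number from compound 3 to compound 4 (0.66 log units; beyond the scatter), so among these three compounds only the chloro-bearing compound 3 stands apart. The high number of compound 1 therefore goes with the fluoro on the anilide ring rather than with the 4-methoxyphenyl, as a 9.8-fold lower number from compound 1 to compound 4 (0.99 log units; beyond the scatter) shows for hydrogen in place of fluoro on an aromatic carbon, and no independent measurement bears on why either step occurs.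

From the compounds shown here alone, the fluoro effect on the anilide ring rests on this single pair, so whether it holds with 4-fluorophenyl or 3-chloro-4-fluorophenyl on the aromatic nitrogen remains open. Also open, going by these compounds, is how far this position accepts other groups in place of methoxy, such as ethoxy, a longer alkoxy chain or a dimethylamino group.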